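Shortening the hydroxamate chain by one carbon

The compounds below may be only part of what the source reports. "The series", "measured", "known", "first", "only" and "open" are said of these compounds alone.

Compound 1, `Nc1nc2cc(-c3nn(CCCCCC(=O)NO)c4ncnc(N)c34)ccc2o1`, gives in a functional assay on A549 cells (Homo sapiens) for inhibition, read by MTT assay, with a stated time of 72 h (a higher number here means a weaker inhibitor, a lower number a stronger inhibitor), only a limit, > 100000 nM.
Compound 2, `Nc1nc2cc(-c3nn(CCCC(=O)NO)c4ncnc(N)c34)ccc2o1`, gives in this assay only a limit, > 100000 nM.

For the measured compounds named here, compound 2 stands at the limit of this assay, so the one measured step touching the chain, a step that the two limits leave unreadable from compound 1 to compound 2, cannot be read. Compound 3, `Nc1nc2cc(-c3nn(CCCCC(=O)NO)c4ncnc(N)c34)ccc2o1`, differs from compound 2 by (hydroxycarbamoyl)methyl in place of hydroxycarbamoyl on a saturated chain carbon, three bonds along the chain from an aromatic nitrogen. Since both shown values sit at the limit (the limit of > 100000 nM in this assay, at which 2 of the 2 values shown sit), they give no direction and no size for this change. The step that the limit leaves unreadable from compound 2 to compound 3 is expected to stay within the scatter, most likely as a further limit. For compound 3 the estimate in this assay is 150000 nM, within 50000 nM to 500000 nM.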

Compound 3, half-maximal inhibitory concentration: > 100000 nM
Compound 3 ended at the assay's limit; the forecaster's own chance of this, stated with the estimate: 80%; the middle value does not contradict the limit.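

No step among compound 1, compound 2 and compound 3 can be read, as each gives only a limit: the limit of > 100000 nM in this assay, at which 3 of the 3 values shown sit.

As far as these compounds go, whether any of these chain lengths gives a readable inhibition value, and how length would then change it, stays open.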